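Phenyl for isobutyl on the oxygen-bound chain

The compounds below may be only part of what the source reports. "The series", "measured", "known", "first", "only" and "open" are said of these compounds alone.

Measured in a functional assay on brain (Rattus norvegicus, strain Wistar) for inhibition; on this read-out higher numbers stand for weaker inhibition and lower numbers for stronger inhibition:
- compound 1 `CCCCc1ccc(-c2c(C)[nH]c(=O)n2C)cc1`: 10700 nM
- compound 2 `Cc1[nH]c(=O)n(C)c1-c1ccc(OC(C)C)cc1`: 20400 nM
- compound 3 `Cc1[nH]c(=O)n(C)c1-c1ccc(OCCC(C)C)cc1`: 6600 nM

Compound 3 cannot be told apart from its nearest neighbour, as the numbers show a 1.6-fold lower number from compound 1 to compound 3 (0.21 log units; within the scatter). It stands clearly apart only at the other end of the set, with a 3.1-fold lower number from compound 2 to compound 3 (0.49 log units; beyond the scatter).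

The next compound is compound 4 `Cc1[nH]c(=O)n(C)c1-c1ccc(OCc2ccccc2)cc1`, which keeps the shared core. Its change is phenyl in place of isobutyl on a saturated chain carbon bound to an oxygen on an aromatic ring. Cut one bond further out, the same difference reads isopentyl to benzyl.

Among the compounds with values here, the closest guide is the only other measured change of the group on that oxygen, a 3.1-fold lower number from compound 2 to compound 3 (0.49 log units; beyond the scatter), a modest step. The other two steps stayed within the scatter: a 1.9-fold higher number from compound 1 to compound 2 (0.28 log units; within the scatter) and a 1.6-fold lower number from compound 1 to compound 3 (0.21 log units; within the scatter). Within the data shown here, none of the measured compounds carries a ring in this group, so the data offer no direction for the swap, and a wide range is warranted.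

The expected result is a 1.1-fold higher number from compound 3 to compound 4 (0.03 log units; within the scatter), so no change beyond the scatter is anticipated in this assay. For compound 4 the estimated value is 7000 nM, with an expected range from 2500 nM to 20000 nM.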

Compound 4, half-maximal inhibitory concentration: 6700 nM
Compound 4: the middle estimate sits 1.0-fold (0.02 log units) above what was measured, and the stated range covers the measured number.
By their numbers in this assay, from the lowest: compounds 3, 4, 1 and 2 (each within the scatter of the next, the first and the last beyond it).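

Within the data shown here, the phenyl group is the first ring in this part of the molecule, and in this assay it leaves the reading unchanged: a 1.0-fold higher number from compound 3 to compound 4 (0.01 log units; within the scatter). On a saturated chain carbon bound to an oxygen on an aromatic ring, isobutyl and phenyl therefore cannot be told apart here, so a six-membered aromatic ring of carbon only is accepted in this assay with no measurable gain or loss. The gap to the isopropoxy compound also recurs with this quite different group, a 3.0-fold lower number from compound 2 to compound 4 (0.48 log units; beyond the scatter), which means that the earlier separation from compound 2 is not tied to the isopentyl chain alone, although no available evidence explains this result.

Still open, going by these compounds, is whether the phenyl ring itself can be used to move the number, for example with a fluorine atom or a methoxy group on it, or with a pyridine ring in its place. Also unresolved is how a longer link between the oxygen and the ring, as in a phenethyl group, or an amine or a carboxylic acid at the end of the chain, would read in this assay.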